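A Cyanophenyl Replacement on the Ring Nitrogen

A few compounds are considered here, and "the series" means these few. Any claim that something is new, unique, unknown or untested is made for them only; others in the source may bear on it.

Measured so far:
compound 1 `Nc1ccccc1NC(=O)c1ccc(CSC(=S)N2CCN(Cc3ccccn3)CC2)cc1`: 61.4%
compound 2 `CCN(Cc1ccncc1)C(=S)SCc1ccc(C(=O)Nc2ccccc2N)cc1`: 77.7%

In a functional assay on HeLa cells (Homo sapiens) for antiproliferative activity, read by CCK-8 assay, with a stated time of 72 h, tested at 8 uM (on this read-out lower numbers stand for a weaker effect and higher numbers for a stronger effect at the one concentration tested), compound 1 gives 61.4%, the lower of the two numbers, while compound 2 gives 77.7%, a gap beyond the scatter. Compound 3 `N#Cc1ccc(N2CCN(C(=S)SCc3ccc(C(=O)Nc4ccccc4N)cc3)CC2)cc1` has not been measured. It differs from compound 1 in one place: 4-cyanophenyl in place of (pyridin-2-yl)methyl on an amine nitrogen in a ring. Among the compounds with values here, with no step between measured compounds available, the size of this change is uncertain, and no step beyond the scatter is expected; the step from compound 1 to compound 3 is estimated at a number 3.6 percentage points higher from compound 1 to compound 3 (within the scatter). Compound 3 is therefore expected to give 65%, with a range from 45% to 85%.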

Compound 3, a percentage reported as inhibition, at one concentration (the size of the read-out at that concentration, not a potency): 70.6%
Compound 3: the middle estimate sits 5.6 percentage points below what was measured; low and high end bracket the measured number.
By their numbers in this assay, from the lowest: compounds 1, 3 and 2 (each within the scatter of the next, the first and the last beyond it).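

In this assay, within the data shown here, the change reads as a number 9.2 percentage points higher from compound 1 to compound 3 (within the scatter) and gives the first step at this position. It shows that 4-cyanophenyl can take the place of (pyridin-2-yl)methyl on this amine nitrogen in a ring with no difference beyond the usual scatter, although an aromatic ring of carbon only with a nitrile replaces one with a hetero atom. No evidence at hand bears on the reason for this result.

Still open, from the compounds shown here alone, is how a simple methyl, a carboxylic acid or an amine on the same nitrogen would read. A single concentration also leaves the potency of compound 1 and compound 3 unresolved.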